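This account rests on a few compounds, and the source may have more. Where it says the series, first, only, none or still open, it means among the compounds named here.

Measured in an assay on isolated protein for inhibition of aldehyde dehydrogenase 1A1 (Homo sapiens), read by spectrophotometry, tested at 10 uM; on this read-out higher numbers stand for more inhibition at the one concentration tested (going by the name of the read-out) and lower numbers for less inhibition:

Compound 1 `CC(C)=CCn1c(CN2CCN(C(=O)C3CC3)CC2)nc2ccccc21`: 74.3%
Compound 2 `CCn1c(CN2CCN(C(=O)C3CC3)CC2)nc2ccccc21`: 20.8%
Compound 3 `O=C(C1CC1)N1CCN(Cc2nc3ccccc3n2Cc2ccccc2F)CC1`: 40.7%

On these three numbers compound 3 stands second highest. It sits above compound 2, the step being a number 19.9 percentage points higher from compound 2 to compound 3 (beyond the scatter), and below compound 1, the step from compound 1 down to compound 3 being a number 33.6 percentage points lower from compound 1 to compound 3 (beyond the scatter). The largest of the three steps, a number 53.5 percentage points lower from compound 1 to compound 2 (beyond the scatter), shows how much the group on the saturated chain carbon bound to the aromatic nitrogen matters on this read-out.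

Compound 4 `Cc1ccc(Cn2c(CN3CCN(C(=O)C4CC4)CC3)nc3ccccc32)cc1` has not yet been measured. It differs from compound 3 by 4-methylphenyl in place of 2-fluorophenyl on a saturated chain carbon bound to an aromatic nitrogen. None of the three measured steps alters the substituent on an aryl group at this place; all of them exchange the whole group. The only thing the data show is that an aryl at this place, in compound 3, gives more than methyl in compound 2 and less than the 2-methylprop-1-en-1-yl group in compound 1, so the expected step of a number 4.3 percentage points higher from compound 3 to compound 4 (within the scatter) is small and within the scatter, in either direction. Compound 4 is therefore estimated at 45%, with a range from 22% to 68%.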

Compound 4, a percentage reported as inhibition, at one concentration (the size of the read-out at that concentration, not a potency): 51.5%
Beside the measured number, compound 4's estimate is 6.5 percentage points below it; the measured number falls inside the stated range.
By their numbers in this assay, from the lowest: compound 2; then compound 3; then compound 4; then compound 1.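

In this assay, the aryl groups at this place, on a saturated chain carbon bound to an aromatic nitrogen, are not interchangeable: 4-methylphenyl in place of 2-fluorophenyl gives a number 10.8 percentage points higher from compound 3 to compound 4 (beyond the scatter), so what the ring carries counts here, and not only the presence of an aryl group. The new compound keeps the order the earlier ones suggested for an aryl group, with a number 30.7 percentage points higher from compound 2 to compound 4 (beyond the scatter) on going from methyl to 4-methylphenyl and a number 22.8 percentage points lower from compound 1 to compound 4 (beyond the scatter) on going from 2-methylprop-1-en-1-yl to 4-methylphenyl, so this second aryl group also fails to reach the open-chain alkene of compound 1. No supporting evidence bears on why these groups differ.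

Compound 3 and compound 4 differ both in the kind of substituent and in where it sits on the ring, so these compounds cannot separate those two changes, and unsubstituted phenyl would be needed as a common reference for both. From the compounds shown here alone, it also stays open whether the double bond of compound 1 matters, which a saturated 2-methylpropyl group at the same place would test.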